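The source may report more compounds than this note shows. Statements on the series, on what has been measured and on what is new or still open speak of the compounds shown alone.

Measured in a functional assay on MCF7 cells (Homo sapiens) for inhibition, read by MTT assay, with a stated time of 24 h; on this read-out lower numbers stand for stronger inhibition of growth and higher numbers for weaker inhibition of growth:
- compound 1 `Cn1cc(-c2nc3ccccc3n2C(=O)c2ccccc2)c2ccccc21`: 43700 nM
- compound 2 `COc1ccccc1C(=O)n1c(-c2cn(C)c3ccccc23)nc2ccccc21`: 32100 nM
- compound 3 `COc1ccc2c(c1)c(-c1nc3ccccc3n1C(=O)c1ccccc1)cn2C`: 38400 nM

These three values lie close together. Compound 3, at 38400 nM, falls within the scatter of both compound 1 and compound 2, so no ranking can be drawn among them.

Compound 4 `COc1ccc2c(c1)c(-c1nc3ccccc3n1C(=O)c1ccccc1OC)cn2C` differs from compound 3 by a single change: methoxy in place of hydrogen on an aromatic carbon. A methoxy takes the place of a hydrogen on an aromatic carbon, turning benzoyl into (2-methoxyphenyl)carbonyl.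

Going by the values given here, two measured steps bear on this change. The closer guide is a 1.4-fold lower number from compound 1 to compound 2 (0.13 log units; within the scatter), the same benzoyl change made on a compound without the methoxy on the core. The other is a 1.1-fold lower number from compound 1 to compound 3 (0.06 log units; within the scatter), where the methoxy enters on the core instead. Both steps are small, but neither shows what happens when the two methoxy groups are present together, as they are in compound 4.

In this assay, the expectation is therefore a slight drift towards a lower number, with no step beyond the scatter. The estimated change is a 1.3-fold lower number from compound 3 to compound 4 (0.11 log units; within the scatter). For compound 4 the expected value is 30000 nM, with an estimated range from 16000 nM to 55000 nM.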

Compound 4, concentration for 50% growth inhibition: 23900 nM
For compound 4 the middle estimate is 1.3-fold (0.10 log units) above the measured one, within the range that was stated.
By their numbers in this assay, from the lowest: compounds 4, 2, 3 and 1 (each within the scatter of the next).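

Only compound 4 carries both methoxy groups, so it is the one test of whether each change still holds when the other is present. In this assay, the change from benzoyl to (2-methoxyphenyl)carbonyl on a core that already has its methoxy gives a 1.6-fold lower number from compound 3 to compound 4 (0.21 log units; within the scatter), and this matches the same change on the core without that methoxy: the same change on two cores in this assay, a 1.4-fold lower number (0.13 log units; within the scatter) from compound 1 to compound 2 and a 1.6-fold lower number (0.21 log units; within the scatter) from compound 3 to compound 4, 1.2-fold (0.07 log units) apart, within the scatter of two such steps. Read the other way, adding the methoxy on the core when the 2-methoxyphenyl is already present gives a 1.3-fold lower number from compound 2 to compound 4 (0.13 log units; within the scatter), and this also matches its earlier counterpart: the same change on two cores in this assay, a 1.1-fold lower number (0.06 log units; within the scatter) from compound 1 to compound 3 and a 1.3-fold lower number (0.13 log units; within the scatter) from compound 2 to compound 4, 1.2-fold (0.07 log units) apart, within the scatter of two such steps. In these four compounds, then, neither methoxy shows any sign of altering what the other does, though every step stays within the scatter, so neither can be said to change growth inhibition.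

What these compounds leave open is whether the place ortho to a large group on this six-membered ring can affect growth inhibition at all, since methoxy is the only group shown there. An amine, a carboxylic acid or a longer chain such as butoxy in that place could settle this, as could a methoxy on another carbon of the same ring.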